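A Larger Chain Group in Place of the Acetyl of Compound 1

This account rests on a few compounds, and the source may have more. Where it says the series, first, only, none or still open, it means among the compounds named here.

Measured compounds:
compound 1, `COc1c(N2CCN(CCC(C)=O)C(C)C2)c(F)cc2c(=O)c(C(=O)O)cn(C3CC3)c12`: 9.84 ug/mL
compound 2, `CO/N=C(\C)CCN1CCN(c2c(F)cc3c(=O)c(C(=O)O)cn(C4CC4)c3c2OC)CC1C`: 157 ug/mL
compound 3, `CCO/N=C(\C)CCN1CCN(c2c(F)cc3c(=O)c(C(=O)O)cn(C4CC4)c3c2OC)CC1C`: 88.4 ug/mL

In an ADME assay on Vero cells (Chlorocebus sabaeus) for cytotoxicity, read by MTT assay, with a stated time of 72 h (on this read-out lower numbers stand for higher toxicity in this test and higher numbers for lower toxicity in this test), compound 1 gives 9.84 ug/mL, the lowest of the three numbers; its nearest neighbour is compound 3 and its furthest is compound 2, both beyond the scatter. Compound 4, `COc1c(N2CCN(CC/C(C)=N/NC(N)=O)C(C)C2)c(F)cc2c(=O)c(C(=O)O)cn(C3CC3)c12`, is not yet measured in this assay. It differs from compound 1 in one place: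

a group of 7 heavy atoms (3 carbon, 3 nitrogen, 1 oxygen; no ring) in place of a group of 3 heavy atoms (2 carbon, 1 oxygen; no ring), on a saturated chain carbon, two bonds along the chain from an amine nitrogen in a ring

Two measured steps start from the same acetyl on the same chain carbon of compound 1 and so bear directly on this change: a 16-fold higher number from compound 1 to compound 2 (1.20 log units; beyond the scatter) and a 9.0-fold higher number from compound 1 to compound 3 (0.95 log units; beyond the scatter). The two products of those steps lie close to each other, since a 1.8-fold lower number from compound 2 to compound 3 (0.25 log units; within the scatter). In both cases a larger group without a ring entered where the acetyl left, and in both the number rose well beyond the scatter. The change to compound 4 is of the same kind at the same place, so a rise of comparable size is expected, with an 11-fold higher number from compound 1 to compound 4 (1.05 log units; beyond the scatter) as the estimated step. Compound 4 is therefore expected to give about 110 ug/mL in this assay, within a range of 35 ug/mL to 300 ug/mL.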

Compound 4, half-maximal cytotoxic concentration: 31.3 ug/mL
The estimate for compound 4 lay 3.5-fold (0.55 log units) above the measured number; measured number below the stated range.
By their numbers in this assay, from the lowest: compound 1; then compound 4; then compounds 3 and 2 (each within the scatter of the next).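

With a 3.2-fold higher number from compound 1 to compound 4 (0.50 log units; beyond the scatter) in this assay, the ureido-bearing group also lifts the number over the acetyl, so all three larger groups at this place, in compounds 2, 3 and 4, move the number the same way, though not equally far. Going by these compounds alone, the group on the double-bonded nitrogen now proves to matter: methoxy and ethoxy had stayed within the scatter of each other, whereas ureido in place of them gives a 2.8-fold lower number from compound 3 to compound 4 (0.45 log units; beyond the scatter) and a 5.0-fold lower number from compound 2 to compound 4 (0.70 log units; beyond the scatter), a separation that the earlier compounds did not show. Nothing at hand speaks to what lies behind this separation.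

The compounds shown leave open how a hydroxyl, a plain amine or a phenyl on the double-bonded nitrogen would stand against methoxy, ethoxy and ureido. They also leave open whether a longer chain in place of the ethoxy, or a methyl on the ureido nitrogen, would keep the number near that of the ether-bearing compounds or bring it closer to that of compound 4.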